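The source may report more compounds than this note shows. Statements on the series, on what has been measured and on what is new or still open speak of the compounds shown alone.

Working notes on the series. Compound 1 `COc1ccc2[nH]c3c(c2c1)CCNC31CCN(Cc2c(F)ccc(Cl)c2F)CC1` and compound 2 `COc1ccc2[nH]c3c(c2c1)CCNC31CCN(Cc2ccc(F)c(Cl)c2F)CC1` share one core; in an assay on FRT cells for positive allosteric modulation of Cystic fibrosis transmembrane conductance regulator variant N1303K (Homo sapiens), in the presence of a further agent that is not named here (a higher number here means that more compound is needed for the effect, a lower number that less compound is needed), compound 1 gives 1500 nM and compound 2 gives 4500 nM, the higher of the two numbers, with a 3.0-fold higher number from compound 1 to compound 2 (0.48 log units; beyond the scatter). Compound 3 `COc1ccc2[nH]c3c(c2c1)CCNC31CCN(Cc2ccco2)CC1` differs from compound 2 by furan-2-yl in place of 3-chloro-2,4-difluorophenyl on a saturated chain carbon bound to an amine nitrogen in a ring. Within the data shown here, no measured step swaps the whole aryl group; the one step known only moves halogens within it, so it bears weakly on this change, and the expectation is therefore broad. For compound 3 a step of a 1.8-fold higher number from compound 2 to compound 3 (0.25 log units; within the scatter) is expected, with this assay estimated at 8000 nM, range 2000 nM to 30000 nM.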

Compound 3, half-maximal effective concentration: 16400 nM
For compound 3 the middle estimate is 2.1-fold (0.31 log units) below the measured one; low and high end bracket the measured number.
By their numbers in this assay, from the lowest: compound 1; then compound 2; then compound 3.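

In this assay the exchange of the whole aryl group on this saturated chain carbon gives a 3.6-fold higher number from compound 2 to compound 3 (0.56 log units; beyond the scatter) and, from the other halogen pattern, an 11-fold higher number from compound 1 to compound 3 (1.04 log units; beyond the scatter) as furan-2-yl replaces 3-chloro-2,6-difluorophenyl. Both halogenated phenyl compounds thus give lower numbers than compound 3, whichever of the two halogen patterns is present. No supporting measurement accounts for this result.
Going by these compounds, it remains open whether the higher number of compound 3 goes with the furan ring or with the absence of halogens. Unsubstituted phenyl and 5-chlorofuran-2-yl at this position would separate those two readings.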